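Swapping the sulfonyl group: oxetanyl to isopropyl

The source may hold more compounds than are shown below. What is called first, only, known or untested is meant among the compounds shown, and "the series" means these compounds.

Of the compounds shown here, two sharing one core have been measured in a functional assay on MIA PaCa-2 cells (Homo sapiens) for inhibition, read by MTT assay, with a stated time of 7 days; on this read-out lower numbers stand for stronger inhibition and higher numbers for weaker inhibition. Compound 1 `O=C([C@@H]1CCCN(S(=O)(=O)c2ccc(S(=O)(=O)N3CC[C@@H](O)C3)cc2)C1)N1CCC(F)(F)CC1` gives 210 nM in this assay. Compound 2 `O=C([C@@H]1CCCN(S(=O)(=O)c2ccc(S(=O)(=O)C3COC3)cc2)C1)N1CCC(F)(F)CC1` differs from compound 1 only at one sulfonyl sulfur; in this assay compound 2 gives 110 nM. Within the data shown here, that single measured step, a 1.9-fold lower number from compound 1 to compound 2 (0.28 log units; within the scatter), is the only comparison available, so compound 2 has just one neighbour, compound 1, and the gap between the two sits within the scatter of the method.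

Compound 3 `CC(C)S(=O)(=O)c1ccc(S(=O)(=O)N2CCC[C@@H](C(=O)N3CCC(F)(F)CC3)C2)cc1` differs from compound 2 at the same sulfonyl sulfur: isopropyl in place of oxetan-3-yl on a sulfonyl sulfur. Among the measured compounds shown here, the one measured step at this position, the change from compound 1 to compound 2, stayed within the scatter, which suggests this part of the molecule tolerates substitution without large shifts in this assay. On that basis no step beyond the scatter is expected from compound 2 to compound 3, and the estimated step is a 1.4-fold higher number from compound 2 to compound 3 (0.13 log units; within the scatter). Compound 3 is therefore expected to give about 150 nM in this assay, with a likely range from 60 nM to 400 nM.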

Compound 3, half-maximal inhibitory concentration: 11 nM
Compound 3: middle estimate off by 14-fold (1.13 log units), on the high side; measured number below the stated range.
By their numbers in this assay, from the lowest: compound 3; then compounds 2 and 1 (each within the scatter of the next).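

This position is less tolerant than the first pair suggested: in this assay, isopropyl in place of oxetan-3-yl on the sulfonyl sulfur gives a 10-fold lower number from compound 2 to compound 3 (1.00 log units; beyond the scatter), and isopropyl in place of 3-hydroxypyrrolidin-1-yl gives a 19-fold lower number from compound 1 to compound 3 (1.28 log units; beyond the scatter). Both steps lie beyond the scatter, while compound 1 and compound 2 remain within the scatter of each other, which makes compound 3, with its ringless isopropyl group, the most potent of the three in this read-out. Nothing shown here bears on the reason for this large difference.

The step from compound 2 to compound 3 removes a four-membered ring and the oxygen atom together, and the three compounds leave open which of these changes goes with the lower number. A cyclobutyl group, which would keep a four-membered ring without the oxygen, and an ethyl or tert-butyl group, which would change the size of the ringless chain, could help separate these possibilities.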